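This account rests on a few compounds, and the source may have more. Where it says the series, first, only, none or still open, it means among the compounds named here.

Compound 3 `CCCS(=O)(=O)Nc1ccc(F)c(C(=O)c2n[nH]c3ncc(-c4ccc(S(=O)(=O)NCC)cc4)cc23)c1F` carries a 4-(ethylsulfamoyl)phenyl group, and in an assay for binding affinity to dual specificity mitogen-activated protein kinase kinase 4 (Homo sapiens), read by KINOMEscan, tested at 100 nM (a higher number here means a weaker effect of the compound at the concentration tested, a lower number a stronger effect), compound 3 gives 3%. Its closest relatives are compound 1 `CCCS(=O)(=O)Nc1ccc(F)c(C(=O)c2n[nH]c3ncc(-c4ccc(OC)cc4)cc23)c1F`, which gives 4.2%, and compound 2 `CCCS(=O)(=O)Nc1ccc(F)c(C(=O)c2n[nH]c3ncc(-c4ccc([N+](=O)[O-])cc4)cc23)c1F`, which gives 4.2%. All three numbers sit together: the steps of a number 1.2 percentage points lower from compound 1 to compound 3 (within the scatter) and a number 1.2 percentage points lower from compound 2 to compound 3 (within the scatter) are within the scatter, and so is no change at the digits printed from compound 1 to compound 2 (within the scatter). Compound 4 `CCCS(=O)(=O)Nc1ccc(F)c(C(=O)c2n[nH]c3ncc(-c4ccc(S(N)(=O)=O)cc4C)cc23)c1F` differs from compound 3 in one place: 2-methyl-4-sulfamoylphenyl in place of 4-(ethylsulfamoyl)phenyl on an aromatic carbon. The three measured steps each swapped one group on an aromatic carbon of the same ring and none moved the read-out beyond the scatter, so the expected step of a number 1 percentage points higher from compound 3 to compound 4 (within the scatter) is likewise small. Compound 4 is therefore estimated at 4%, within 1% to 12%.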

Compound 4, a percentage reported as activity, at one concentration (the size of the read-out at that concentration, not a potency): 3.1%
The estimate for compound 4 lay 0.9 percentage points above the measured number, and the stated range covers the measured number.
By their numbers in this assay, from the lowest: compounds 3, 4, 1 and 2 (each within the scatter of the next).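

A ring bearing both a 2-methyl and a sulfamoyl group fits this position as well as the singly substituted rings did in this assay: the read-out stays put (a number 0.1 percentage points higher from compound 3 to compound 4 (within the scatter)), (a number 1.1 percentage points lower from compound 2 to compound 4 (within the scatter)), (a number 1.1 percentage points lower from compound 1 to compound 4 (within the scatter)). The ethyl group on the sulfonamide nitrogen is also not needed to keep the number this low, at least when the methyl is present. The methyl and the ethyl change together here, so their separate contributions cannot be told apart. On these data alone, whether an amine or a carboxylic acid on this ring would keep the number this low remains open. No measurement here explains the result.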